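A plain phenyl in place of 3,4-dimethoxyphenyl

The compounds below may be only part of what the source reports. "The series", "measured", "known", "first", "only" and "open" are said of these compounds alone.

Compound 1 `Cc1ccc2[nH]c(-c3ccc(-c4ccc(-c5ccc(N(C)C)cc5)cc4)cc3)nc2c1` gives 7200 nM
Compound 2 `Cc1ccc2[nH]c(-c3ccc(-c4ccc(-c5cccc(Cl)c5)cc4)cc3)nc2c1` gives 3450 nM
Compound 3 `COc1ccc(-c2ccc(-c3ccc(-c4nc5cc(C)ccc5[nH]4)cc3)cc2)cc1OC` gives 3100 nM

These three values come from a functional assay on ZR-75-1 cells (Homo sapiens) for inhibition, read by sulforhodamine B assay (on this read-out higher numbers stand for weaker inhibition of growth and lower numbers for stronger inhibition of growth), and describe compounds that differ only in one end group on the shared core. Compound 3 and compound 2 lie within the scatter of each other (a 1.1-fold lower number from compound 2 to compound 3 (0.05 log units; within the scatter)). Compound 1 carries the highest number, beyond the scatter from both (a 2.3-fold lower number from compound 1 to compound 3 (0.37 log units; beyond the scatter); a 2.1-fold lower number from compound 1 to compound 2 (0.32 log units; beyond the scatter)).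

Compound 4 `Cc1ccc2[nH]c(-c3ccc(-c4ccc(-c5ccccc5)cc4)cc3)nc2c1` has not yet been measured in this assay. Its change from compound 3 (phenyl in place of 3,4-dimethoxyphenyl on an aromatic carbon) is phenyl in place of 3,4-dimethoxyphenyl on an aromatic carbon, para to a large group. Among the measured compounds shown here, no measured step shows this exact exchange, so the evidence is indirect. For the measured compounds named here, the steps that bear on it are the exchanges of the end group at that same place. Replacing the 3-chlorophenyl of compound 2 with 3,4-dimethoxyphenyl left the number within the scatter (a 1.1-fold lower number from compound 2 to compound 3 (0.05 log units; within the scatter)), while the largest step in the set remains modest (a 2.3-fold lower number from compound 1 to compound 3 (0.37 log units; beyond the scatter)). On these data alone, a step beyond the scatter is therefore not expected, and the direction stays open. The estimated change is small (a 1.2-fold higher number from compound 3 to compound 4 (0.09 log units; within the scatter)). For compound 4 the expected value is 3800 nM, with an estimated range from 1500 nM to 9000 nM.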

Compound 4, concentration for 50% growth inhibition: 27400 nM
Compound 4: middle estimate off by 7.2-fold (0.86 log units), on the low side; measured number above the stated range.
By their numbers in this assay, from the lowest: compounds 3 and 2 (each within the scatter of the next); then compound 1; then compound 4.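

In this assay, the group at this place, on an aromatic carbon para to a large group, matters more than the three substituted end groups had suggested: the bare phenyl of compound 4 stands apart, with an 8.8-fold higher number from compound 3 to compound 4 (0.95 log units; beyond the scatter). The other two exchanges point the same way, with hydrogen in place of chloro giving a 7.9-fold higher number from compound 2 to compound 4 (0.90 log units; beyond the scatter) and hydrogen in place of dimethylamino giving a 3.8-fold higher number from compound 1 to compound 4 (0.58 log units; beyond the scatter). Across these four compounds, each of the three substituted phenyls goes with a lower number than plain phenyl, although compound 1 stays above compound 2 and compound 3, so the choice of substituent still counts.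

Nothing shown here explains why plain phenyl stands apart from the substituted end groups. On these data alone, it remains open whether a lone fluorine, a hydroxyl, an amine or a carboxylic acid on this end phenyl would also bring the number down to the level of compound 2 and compound 3, and whether the same order would hold in other cell lines.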